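Changing the phenyl on the amide nitrogen of compound 1

This account rests on a few compounds, and the source may have more. Where it says the series, first, only, none or still open, it means among the compounds named here.

Measured so far in an assay on isolated protein for inhibition of histone deacetylase 4 (Homo sapiens), with a stated time of 1 h; a lower number here means a stronger inhibitor, a higher number a weaker inhibitor:
compound 1, `Cc1ccc(NC(=O)COc2ccc3cc(/C=C4/SC(=O)NC4=O)ccc3c2)cc1Cl`, gives 1100 nM.
compound 2, `O=C(COc1ccc2cc(/C=C3/SC(=O)NC3=O)ccc2c1)Nc1ccc(Br)cc1`, gives 2900 nM.
compound 3, `O=C(CN1C(=O)S/C(=C/c2ccccn2)C1=O)Nc1nc2ccccc2s1`, gives 9300 nM.

Compound 1 has the lowest number of the three; compound 2 stands nearest to it and compound 3 furthest. Compound 4, `O=C(COc1ccc2cc(/C=C3/SC(=O)NC3=O)ccc2c1)Nc1ccc(F)cc1`, differs from compound 1 in one place: 4-fluorophenyl in place of 3-chloro-4-methylphenyl on an amide-type nitrogen. Going by the values given here, the one measured step that bears on this is a 2.6-fold higher number from compound 1 to compound 2 (0.42 log units; beyond the scatter), which likewise puts a different phenyl on the same nitrogen and moves the number up modestly. A modest step in the same direction, towards weaker inhibition, is therefore expected in this assay. Compound 4 is estimated at 3000 nM, within 1200 nM to 8000 nM, that is a 2.7-fold higher number from compound 1 to compound 4 (0.44 log units; beyond the scatter).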

Compound 4, half-maximal inhibitory concentration: 1600 nM
Beside the measured number, compound 4's estimate is 1.9-fold (0.27 log units) above it, and the stated range covers the measured number.
By their numbers in this assay, from the lowest: compounds 1, 4 and 2 (each within the scatter of the next, the first and the last beyond it); then compound 3.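

In this assay, the step of a 1.5-fold higher number from compound 1 to compound 4 (0.16 log units; within the scatter) and the step of a 1.8-fold lower number from compound 2 to compound 4 (0.26 log units; within the scatter) place compound 4 within reach of both neighbours, even though compound 1 and compound 2 differ beyond the scatter. On this amide-type nitrogen, then, 4-fluorophenyl cannot be told apart from either 3-chloro-4-methylphenyl or the 4-bromophenyl of compound 2. Nothing available gives a reason for these numbers. On these data alone, all three groups here are halogen-bearing phenyl rings, so what a carboxylic acid or an amine on that ring would do stays open. So does the effect of replacing the phenyl with a longer chain.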